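The source may report more compounds than this note shows. Statements on the series, on what has been measured and on what is new or still open speak of the compounds shown alone.

Working notes on the hydroxamic acid series. Of the compounds shown here, three have numbers so far: compound 1 `Cc1ccc(-c2nc(CNc3ccc(C(=O)NO)cc3)n(-c3ccccc3)n2)o1`, compound 2 `Cc1cccc(-n2nc(-c3ccccc3)nc2CNc2ccc(C(=O)NO)cc2)c1` and compound 3 `O=C(NO)c1ccc(NCc2nc(-c3ccc(F)cc3)nn2-c2ccccc2)cc1`. In an assay on Sf9 cells for inhibition of protein deacetylase HDAC6 (Homo sapiens), read by fluorescence, with a stated time of 40 min, tested at 100 nM (on this read-out higher numbers stand for more inhibition at the one concentration tested (going by the name of the read-out) and lower numbers for less inhibition), compound 1 gives 60.7%, compound 2 gives 66% and compound 3 gives 70.9%. Compound 2 sits second of the three, and both of its gaps, to compound 3 and to compound 1, lie within the scatter, so the three measured compounds cannot be ranked against each other.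

Within the data shown here, the one step between compounds that differ in a single place, a number 10.2 percentage points higher from compound 1 to compound 3 (beyond the scatter), concerns the group on the aromatic carbon, not the group on the aromatic nitrogen, so it does not speak to the change under consideration here.

Compound 4 `O=C(NO)c1ccc(NCc2nc(-c3ccccc3)nn2-c2ccc(Cl)cc2)cc1` is not yet measured in this assay. It differs from compound 2 by 4-chlorophenyl in place of 3-methylphenyl on an aromatic nitrogen. Among the measured compounds shown here, no measured step touches this position, so no basis exists for expecting a step beyond the scatter from compound 2 to compound 4 in this assay in either direction; the expected step is no change at the digits printed from compound 2 to compound 4 (within the scatter). Compound 4 is estimated at 66%, with a range from 50% to 80%.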

Compound 4, a percentage reported as inhibition, at one concentration (the size of the read-out at that concentration, not a potency): 55.4%
For compound 4 the middle estimate is 10.6 percentage points above the measured one; low and high end bracket the measured number.
By their numbers in this assay, from the lowest: compounds 4, 1, 2 and 3 (each within the scatter of the next, the first and the last beyond it).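

In this assay, among these compounds, the exchange on the aromatic nitrogen gives a number 10.6 percentage points lower from compound 2 to compound 4 (beyond the scatter) and is the first reading at this position. It shows that the group held there can shift the number, even though 3-methylphenyl and 4-chlorophenyl have the same count of heavy atoms and the same ring and hydrogen-bond counts. Nothing at hand explains this step.

The change swaps methyl for chlorine and also moves the substituent on the phenyl ring, so the compounds shown do not separate these two changes; 3-chlorophenyl and 4-methylphenyl would part them. Also open, going by these compounds, is whether a group of another kind on this nitrogen, such as 4-aminophenyl or 4-carboxyphenyl, would give a number within the scatter of compound 2 or beyond it.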